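Tert-Butyl in Place of Phenyl on a Sulfonamide Series

The source may hold more compounds than are shown below. What is called first, only, known or untested is meant among the compounds shown, and "the series" means these compounds.

Two compounds were measured in a functional assay on A-431 cells (Homo sapiens) for inhibition, read by MTT assay, with a stated time of 72 h; a lower number here means a stronger inhibitor of growth, a higher number a weaker inhibitor of growth:

Compound 1, `O=S(=O)(NCCNCc1ccc(-c2ccccc2)cc1)c1cc(C(F)(F)F)cc(C(F)(F)F)c1`, gives 2400 nM.
Compound 2, `COc1ccc(CNCCCNS(=O)(=O)c2cc(C(F)(F)F)cc(C(F)(F)F)c2)cc1OC`, gives 7000 nM.

Compound 1 stands as the lower of the two numbers, and the gap to compound 2 lies beyond the usual scatter of this assay. Compound 2 differs from compound 1 in several places at once, so its values say nothing about any single change.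

Compound 3, `CC(C)(C)c1ccc(CNCCNS(=O)(=O)c2cc(C(F)(F)F)cc(C(F)(F)F)c2)cc1`, has not yet been measured. It differs from compound 1 in one place: tert-butyl in place of phenyl on an aromatic carbon. Within the data shown here, no pair of measured compounds shows this change, so there is no measured step to lean on. The expected step from compound 1 to compound 3 is therefore modest, possibly not beyond the scatter, with a slight lean toward a weaker inhibitor; the estimate for compound 3 is a 1.3-fold higher number from compound 1 to compound 3 (0.12 log units; within the scatter). Compound 3 is thus expected to give about 3200 nM in this assay, within a range of 1000 nM to 10000 nM.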

Compound 3, concentration for 50% growth inhibition: 16000 nM
Compound 3: middle estimate off by 5.0-fold (0.70 log units), on the low side; the measured number lies above the stated range.
By their numbers in this assay, from the lowest: compound 1; then compound 2; then compound 3.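

In this assay, tert-butyl in place of phenyl on this aromatic carbon, para to a large group, gives a 6.7-fold higher number from compound 1 to compound 3 (0.82 log units; beyond the scatter) and so lies beyond the scatter. This pair is the only one shown that isolates a single change, and it shows that growth inhibition at this position is not retained when the six-membered aromatic ring of carbon only gives way to this ring-free group. Nothing shown gives a measured reason for this step.

As far as these compounds go, whether a cyclohexyl or a pyridyl group on this carbon would bring the number back toward that of compound 1 remains open, and so does whether the loss comes with the absence of an aromatic ring or with the tert-butyl group itself. Also open, from the compounds shown here alone, is whether a longer chain in compound 3 would shift its number.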